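Chloro to Trifluoromethyl: An Expected Cytotoxicity Outcome

The source may report more compounds than this note shows. Statements on the series, on what has been measured and on what is new or still open speak of the compounds shown alone.

Measured so far, in an ADME assay on RAW264.7 cells (Mus musculus) for cytotoxicity, read by MTT assay, with a stated time of 48 h; on this read-out higher numbers stand for lower toxicity in this test and lower numbers for higher toxicity in this test:
Compound 1, `CC(=O)OC[C@H]1O[C@H](OC[C@@H](Cn2cc(CN(c3nc(-c4ccc(Cl)cc4)no3)C3CCCCC3)nn2)OC(C)=O)C=C[C@@H]1OC(C)=O`, gives 35.5 ug/mL.
Compound 2, `C#CCN(c1nc(-c2cccc(C)c2)no1)C1CCCCC1`, gives 25.9 ug/mL.
Compound 3, `C#CCN(c1nc(-c2ccc(C(F)(F)F)cc2)no1)C1CCCCC1`, gives 38.3 ug/mL.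

Compound 1 sits between compound 3 and compound 2 on these numbers, and both gaps lie within the usual scatter of repeated measurement, so the three values cannot be told apart. Compound 4, `CC(=O)OC[C@H]1O[C@H](OC[C@@H](Cn2cc(CN(c3nc(-c4ccc(C(F)(F)F)cc4)no3)C3CCCCC3)nn2)OC(C)=O)C=C[C@@H]1OC(C)=O`, keeps the whole of compound 1 except for one change: trifluoromethyl in place of chloro on an aromatic carbon. Among the measured compounds shown here, no pair of measured compounds differs in only one place, so no measured step guides this exchange directly; compound 3, which carries the same trifluoromethyl group, sits close to compound 2 in this assay. The step from compound 1 to compound 4 is therefore expected to be small, a 1.1-fold higher number from compound 1 to compound 4 (0.03 log units; within the scatter), in no clear direction beyond the scatter. Compound 4 is estimated at 38 ug/mL, within 20 ug/mL to 70 ug/mL.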

Compound 4, half-maximal cytotoxic concentration: 64.1 ug/mL
For compound 4 the middle estimate is 1.7-fold (0.23 log units) below the measured one, within the range that was stated.
By their numbers in this assay, from the lowest: compounds 2, 1, 3 and 4 (each within the scatter of the next, the first and the last beyond it).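

In this assay, the exchange of chloro for trifluoromethyl on this aromatic carbon, para to a large group, reads as a 1.8-fold higher number from compound 1 to compound 4 (0.26 log units; within the scatter), so the two groups cannot be told apart at this position. Among the compounds shown here, this is the first direct reading of the exchange, since the earlier compounds offered no pair differing in one place. Nothing available here speaks to the cause of this result. On these data alone, whether an amine, a nitrile or a carboxylic acid on the same carbon would also stay within the scatter remains open.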